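Aryl ether change in a prostacyclin synthase inhibitor pair

The compounds below may be only part of what the source reports. "The series", "measured", "known", "first", "only" and "open" are said of these compounds alone.

Compound 2 `CSc1ccc(OC(C)(C)C2OCC(C/C=C\CCC(=O)O)C(c3cccnc3)O2)c([N+](=O)[O-])c1` and compound 1 `O=C(O)CC/C=C\CC1COC(c2ccc(Cl)cc2Cl)OC1c1cccnc1` share a core and differ in the aryl ether. In an assay for inhibition of prostacyclin synthase (Homo sapiens), using microsomes (a lower number here means a stronger inhibitor, a higher number a weaker inhibitor), compound 1 gives 2500 nM. In this assay compound 2 gives 5000 nM, a number that lies within the usual scatter of the value of compound 1, so the two cannot be told apart. Compound 3 `CSc1ccccc1OC(C)(C)C1OCC(C/C=C\CCC(=O)O)C(c2cccnc2)O1` has not been measured. It differs from compound 2 as follows: a group of 8 heavy atoms (7 carbon, 1 sulfur; one six-membered aromatic ring of carbon only) in place of a group of 11 heavy atoms (7 carbon, 1 nitrogen, 2 oxygen, 1 sulfur; one six-membered aromatic ring of carbon only), on an oxygen on a saturated carbon. Among the measured compounds shown here, no measured pair covers this change, so the expectation rests on the two values alone. Compound 3 is expected to give about 4000 nM, with a range of 1500 nM to 12000 nM. The step of a 1.3-fold lower number from compound 2 to compound 3 (0.10 log units; within the scatter) is thus expected to stay within the scatter.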

Compound 3, half-maximal inhibitory concentration: > 100000 nM
Compound 3 gave a limit, no number (the forecaster's own chance of this, stated with the estimate: 5%); at least 25-fold (1.39 log units) between middle value and limit.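

On an oxygen on a saturated carbon, placing 2-(methylsulfanyl)phenyl where the group of 11 heavy atoms stood is far from neutral: this assay shows an at least 20-fold higher number from compound 2 to compound 3 (1.30 log units; beyond the scatter). Among the compounds shown here, the inhibition read-out therefore depends strongly on the aryl group at this position, which the earlier compounds did not show. The result for compound 3 is a limit of the assay, not a number: the limit of > 100000 nM in this assay, at which 1 of the 3 values shown sits.

From the compounds shown here alone, the true size of the step remains open. Going by these compounds, it also remains open which atoms of the departing group carry the difference, and whether a nitrile or an amine on the same aromatic ring would return the number to that of compound 2.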